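Swapping the Pyridinyl-Ethenyl Arm of Compound 1

This account rests on a few compounds, and the source may have more. Where it says the series, first, only, none or still open, it means among the compounds named here.

Compound 1 `COC(=O)/C=C/c1cccc(N(Cc2ccc(/C=C/c3ccccn3)cc2)C(=O)C2CCCCC2)c1` was tested in an assay on isolated protein with Bile acid receptor (Homo sapiens) as the target (a lower number here means that less compound is needed, a higher number that more compound is needed for the effect), where compound 1 gives 309 nM. That is the lowest of the two numbers measured here, but its nearest neighbour, compound 2 `COC(=O)/C=C/c1cccc(N(Cc2ccc(/C=C/c3ccccn3)cc2)C(=O)C(C)C)c1`, sits within the scatter: compound 2 gives 310 nM, and the step of a 1.0-fold higher number from compound 1 to compound 2 (0.00 log units; within the scatter) shows no change beyond the scatter. Compound 3 `COC(=O)/C=C/c1cccc(N(Cc2ccc(/C=C/C(=O)OC(C)(C)C)cc2)C(=O)NCc2ccccc2)c1` gives only > 1000 nM, which is a limit of the assay rather than a number, namely (the limit of > 1000 nM in this assay, at which 1 of the 3 values shown sits).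

Compound 4 `COC(=O)/C=C/c1cccc(N(Cc2ccc(-c3cccc(C(C)=O)c3)cc2)C(=O)C2CCCCC2)c1` differs from compound 1 in one place: 3-acetylphenyl in place of 2-(pyridin-2-yl)ethenyl on an aromatic carbon. Among the measured compounds shown here, no measured step touches this part of the molecule; the only one-place step changes a group on a carbonyl carbon, and compound 3 differs from compound 1 in several places at once. The expectation therefore rests on the change itself, two groups alike in what is counted for them. The expected step of a 1.6-fold higher number from compound 1 to compound 4 (0.21 log units; within the scatter) is modest. Compound 4 is estimated at 500 nM, within 150 nM to 2000 nM.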

Compound 4, half-maximal effective concentration: 227 nM
Compound 4: middle estimate off by 2.2-fold (0.34 log units), on the high side; measured number inside the range.
By their numbers in this assay, from the lowest: compounds 4, 1 and 2 (each within the scatter of the next). At a limit, above all of these: compound 3.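

In this assay the swap to 3-acetylphenyl gives a 1.4-fold lower number from compound 1 to compound 4 (0.13 log units; within the scatter) and so does not separate the two groups. This aromatic carbon, para to a large group, can therefore carry a ring of carbon only with an acetyl group in place of the 2-(pyridin-2-yl)ethenyl arm, and in this one pair the value stays within the scatter without the ring nitrogen or the ethenyl link. Nothing at hand explains why the two groups give such similar values.

As far as these compounds go, it remains open whether a carboxylic acid or an amine in place of the acetyl group would keep the value in this range. Also open, from the compounds shown here alone, is whether the isopropyl group on the carbonyl carbon, which matches cyclohexyl alongside the pyridinyl arm, would do the same alongside 3-acetylphenyl.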